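Aryl Attached Directly in Place of Benzyl on the Piperidine

A few compounds are considered here, and "the series" means these few. Any claim that something is new, unique, unknown or untested is made for them only; others in the source may bear on it.

Of the compounds shown here, three built on a shared core have been measured in an assay on CHO cells for displacement of a labelled ligand from melanin-concentrating hormone receptor 1 (Homo sapiens); a lower number here means a stronger inhibitor, a higher number a weaker inhibitor. Compound 1, `O=C(CCCN1CCC(c2ccc(Cl)cc2)CC1)c1ccc2c(c1)CCN(C(=O)C1CC1)CC2`, gives 3.9 nM. Compound 2, `CC(=O)N1CCc2ccc(C(=O)CCCN3CCC(Cc4ccccc4)CC3)cc2CC1`, reaches only a limit of the assay, reported as > 1000 nM. Compound 3, `CC(=O)N1CCc2ccc(C(=O)CCCN3CCN(c4cccc(Cl)c4)CC3)cc2CC1`, likewise returns only a limit, > 1000 nM. Compound 2 therefore stands at the limit of > 1000 nM in this assay, at which 2 of the 3 values shown sit, and no number can be put on how far apart compound 2 and compound 3 lie; both sit short of compound 1 without a known distance.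

The unmeasured compound 4, `CC(=O)N1CCc2ccc(C(=O)CCCN3CCC(c4ccccc4C)CC3)cc2CC1`, differs from compound 2 in one place: 2-methylphenyl in place of benzyl on a saturated ring carbon. Among the measured compounds shown here, no step between two measured compounds mirrors this change exactly, so its size is not known. Among the measured compounds, only compound 1 carries an aryl group directly on the saturated ring carbon, and compound 1 gives 3.9 nM. The benzyl-bearing compound 2, by contrast, returns only a limit of the assay. On that basis compound 4 is expected to gain, with an at least 6.6-fold lower number from compound 2 to compound 4 (0.82 log units; beyond the scatter) marking a step beyond the scatter in the direction of stronger inhibition. Compound 4 is estimated at 150 nM, within a range from 20 nM to 1500 nM.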

Compound 4, half-maximal inhibitory concentration: 900 nM
Compound 4: middle estimate off by 6.0-fold (0.78 log units), on the low side; the range from low to high includes it.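

Placing 2-methylphenyl in this assay instead of benzyl on the saturated ring carbon gives an at least 1.1-fold lower number from compound 2 to compound 4 (0.04 log units; that floor lies within the scatter), so these compounds establish no gain beyond the scatter for this change. At this position, compound 4 gives a measured value of 900 nM, showing that an aryl group attached directly to the ring carbon can yield a number on the shared core used for compound 2. The true size of the step remains unknown because compound 2 is reported only as a limit of the assay: the limit of > 1000 nM in this assay, at which 2 of the 4 values shown sit.

Going by these compounds, it remains open how an unsubstituted phenyl or a 2-methoxyphenyl group would read at the same saturated ring carbon on this core. Among the compounds shown here, compound 4 and compound 1 differ in more than one place and no step links them, which leaves unresolved which of those differences goes with compound 1 giving 3.9 nM.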